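The source may hold more compounds than are shown below. What is called first, only, known or untested is meant among the compounds shown, and "the series" means these compounds.

Compound 1 `C=C(c1ccc(Cl)c(Cl)c1Cl)C1COC2(CCCC2)OO1` and compound 3 `C=C(c1ccc(Cl)c(Cl)c1)C1COC2(CCCC2)OO1` share one core, while compound 2 `C=C(c1ccc(Cl)c(Cl)c1Cl)C1COC(C)(C)OO1` and compound 4 `C=C(c1ccc(Cl)cc1Cl)C1COC(C)(C)OO1` share another; the difference between the two cores is not broken down here. In a functional assay on A549 cells (Homo sapiens) for inhibition, read by MTT assay, with a stated time of 72 h (on this read-out lower numbers stand for stronger inhibition and higher numbers for weaker inhibition), compound 1 gives 690 nM, compound 3 gives 4680 nM, and compound 2 gives 52100 nM. From compound 1 to compound 3 the change is hydrogen in place of chloro on an aromatic carbon, and it brought a 6.8-fold higher number from compound 1 to compound 3 (0.83 log units; beyond the scatter). From compound 2 to compound 4 the change is hydrogen in place of chloro on an aromatic carbon. This is the same kind of change, though the place differs: here it is ortho to two chloro groups and meta to a large group, whereas before it was ortho to a chloro group, ortho to a large group and meta to a chloro group. Because that earlier step was a 6.8-fold higher number from compound 1 to compound 3 (0.83 log units; beyond the scatter), a step of about a 2.9-fold higher number from compound 2 to compound 4 (0.46 log units; beyond the scatter) is expected in this assay, though compound 2 already gives a high number and the assay may report only a limit. Compound 4 is therefore estimated at 150000 nM in this assay.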

Compound 4, half-maximal inhibitory concentration: 92600 nM
Compound 4: middle estimate off by 1.6-fold (0.21 log units), on the high side, and the stated range covers the measured number.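

In this assay the swap of chloro for hydrogen gave a 1.8-fold higher number from compound 2 to compound 4 (0.25 log units; within the scatter) and so, at this place on this core, it cannot be told apart from repeat-to-repeat variation. The size of the step did not carry over from one core to the other: the same change on two cores in this assay, a 6.8-fold higher number (0.83 log units; beyond the scatter) from compound 1 to compound 3 and a 1.8-fold higher number (0.25 log units; within the scatter) from compound 2 to compound 4, 3.8-fold (0.58 log units) apart, beyond the scatter of two such steps

This does not show why, since the two steps differ both in the core and in where the chloro sat on the aromatic ring, and a single pair on each core cannot separate those two differences.

Still open, from the compounds shown here alone, is how the step would look if the same ring place were changed on both cores. Also open, going by these compounds, is how a methoxy group or an amine on that aromatic carbon would compare with chloro and hydrogen.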